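The source may report more compounds than this note shows. Statements on the series, on what has been measured and on what is new or still open speak of the compounds shown alone.

Measured compounds in a functional assay on SK-BR-3 cells (Homo sapiens) for inhibition (a lower number here means a stronger inhibitor, a higher number a weaker inhibitor), are these
compound 1 `COc1c(C)cnc(CN2CC(=O)N(CC(C)C)c3c(Cl)nc(N)nc32)c1C` gives 10 nM
compound 2 `COc1c(C)cnc(CN2c3nc(N)nc(Cl)c3NC(=O)[C@@H]2CC(C)C)c1C` gives 230 nM
compound 3 `COc1c(C)cnc(CN2CC(=O)N(C)c3c(Cl)nc(N)nc32)c1C` gives 460 nM

Compound 2 (230 nM) lies within the scatter of compound 3 (460 nM) and is clearly weaker than compound 1 (10 nM). The next compound, compound 4 `COc1c(C)cnc(CN2c3nc(N)nc(Cl)c3NC(=O)[C@@H]2C)c1C`, has not yet been measured. It departs from compound 2 by one change: hydrogen in place of isopropyl on a saturated chain carbon bound to a saturated ring carbon. In other words, hydrogen stands in place of isopropyl on a saturated chain carbon bound to a saturated ring carbon, which turns isobutyl to methyl.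

For the measured compounds named here, only one measured step bears on this. The same loss of isopropyl, made on a saturated chain carbon bound to an amide-type nitrogen in a ring, gave a 46-fold higher number from compound 1 to compound 3 (1.66 log units; beyond the scatter) and was large. That step lies elsewhere in the molecule and started from a far lower number, so it may not carry over in full. A clear rise in this assay is still expected, probably somewhat smaller, and the estimated step is an 11-fold higher number from compound 2 to compound 4 (1.04 log units; beyond the scatter) in this account. For compound 4 the estimated value is 2500 nM, with an expected range from 600 nM to 10000 nM.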

Compound 4, half-maximal inhibitory concentration: 250 nM
For compound 4 the middle estimate is 10-fold (1.00 log units) above the measured one; measured number outside the range, below it.
By their numbers in this assay, from the lowest: compound 1; then compounds 2, 4 and 3 (each within the scatter of the next).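

In this assay, isobutyl gives way to methyl on this saturated ring carbon with a 1.1-fold higher number from compound 2 to compound 4 (0.04 log units; within the scatter), so the number for this pair does not follow the size of the chain at this position. The earlier step suggested that losing isopropyl would be costly, but the change proves to have no single size across the two cores shown: the same change on two cores in this assay, a 46-fold higher number (1.66 log units; beyond the scatter) from compound 1 to compound 3 and a 1.1-fold higher number (0.04 log units; within the scatter) from compound 2 to compound 4, 42-fold (1.63 log units) apart, beyond the scatter of two such steps. Among the compounds shown, only the one with the isobutyl group on the amide-type nitrogen in a ring, compound 1, gives 10 nM.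

The compounds shown leave open whether any group at the saturated ring carbon can bring the number down towards that of compound 1. A longer chain, a phenyl ring or a primary amine at this position could each test that.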